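Methoxy on the Saturated Chain of Compound 1

The source may report more compounds than this note shows. Statements on the series, on what has been measured and on what is new or still open speak of the compounds shown alone.

For the measured compounds named here, compound 1 `Cc1cccc(/C(CCN2CCN(c3ccccn3)CC2)=N/O)c1` is the only compound with a measured number in a functional assay on HEK293 cells with D(4) dopamine receptor (Homo sapiens) as the target, read by FLIPR; on this read-out lower numbers stand for an effect already at smaller amounts and higher numbers for an effect only at larger amounts of compound; compound 1 gives 2.3 nM. Compound 2 `Cc1ccc(OCc2ccccc2)c(/C(CCN2CCN(c3ccccn3)CC2)=N/O)c1` reaches only a limit of this assay: compound 2 gives > 10000 nM. Going by the values given here, the single measured step, an at least 4300-fold higher number from compound 1 to compound 2 (3.63 log units; beyond the scatter), ends at the limit of > 10000 nM in this assay, at which 1 of the 2 values shown sits. Compound 3 `COC(CN1CCN(c2ccccn2)CC1)/C(=N\O)c1cccc(C)c1` differs from compound 1 by methoxy in place of hydrogen on a saturated chain carbon bound to a carbon with a double bond to nitrogen and a saturated chain carbon. The step of an at least 4300-fold higher number from compound 1 to compound 2 (3.63 log units; beyond the scatter) changes a different place with a different group, so for compound 3 only a modest rise in the number is expected, a 6.5-fold higher number from compound 1 to compound 3 (0.81 log units; beyond the scatter). Compound 3 is estimated at 15 nM, between 3 nM and 100 nM.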

Compound 3, half-maximal effective concentration: 34.5 nM
Compound 3: middle estimate off by 2.3-fold (0.36 log units), on the low side, within the range that was stated.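

In this assay, the saturated chain carbon bound to a carbon with a double bond to nitrogen and a saturated chain carbon proves sensitive to change: methoxy in place of hydrogen gives a 15-fold higher number from compound 1 to compound 3 (1.18 log units; beyond the scatter). Even so, this change leaves a measurable number, so this position tolerates methoxy to some extent. Compound 2 alone stands at a limit of the assay rather than at a number: the limit of > 10000 nM in this assay, at which 1 of the 3 values shown sits.

Methoxy is the only group shown on this carbon. As far as these compounds go, how a methyl, a hydroxyl or an amine there would compare remains open.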